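The source may hold more compounds than are shown below. What is called first, only, known or untested is meant among the compounds shown, and "the series" means these compounds.

Compound 1 `O=C(Nc1cccc(-n2cc(-c3ccncc3)c(-c3cc(O)cc(Cl)c3)n2)c1)Nc1ccc(Cl)c(C(F)(F)F)c1` gives 1% in a functional assay on Hs-578T cells (Homo sapiens) for inhibition, read by sulforhodamine B assay, with a stated time of 48 h, tested at 100 uM; on this read-out higher numbers stand for a weaker effect at the one concentration tested and lower numbers for a stronger effect.
Compound 2 `O=C(Nc1cccc(-n2cc(-c3ccncc3)c(-c3cc(O)cc(Cl)c3)n2)c1)Nc1ccc(Cl)c(Cl)c1` gives 9% in this assay.
Compound 3 `COc1cc(Cl)cc(-c2nn(-c3cccc(NC(=O)Nc4ccc(Cl)c(Cl)c4)c3)cc2-c2ccncc2)c1` gives 28% in this assay.

Among these three numbers compound 3 stands highest, the weakest effect of the set at the single concentration used; compound 2 is nearest to it and compound 1 furthest, both beyond the scatter. Two single-point changes connect the measured compounds: a number 8 percentage points higher from compound 1 to compound 2 (within the scatter), and a number 19 percentage points higher from compound 2 to compound 3 (beyond the scatter).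

Compound 4 `COc1cc(Cl)cc(-c2nn(-c3cccc(NC(=O)c4cccc(C(F)(F)F)c4)c3)cc2-c2ccncc2)c1` is the next compound, unmeasured in this assay. It differs from compound 3 by 3-(trifluoromethyl)phenyl in place of (3,4-dichlorophenyl)amino on a carbonyl carbon. Neither measured step speaks directly to this change: both of them leave the carbonyl carbon and its two amide-type nitrogens untouched. The step from compound 1 to compound 2 is the nearest analogy, since it also swaps chloro for trifluoromethyl on an outer aromatic ring, and it stayed within the scatter. The loss of an amide-type nitrogen with its hydrogen-bond donor, however, is a change of a kind the three measured compounds do not sample, so the direction is open. Compound 4 is therefore expected to give 40%, between 15% and 75%, a step of a number 12 percentage points higher from compound 3 to compound 4 (beyond the scatter) that is expected to be modest at most, with the wide range reflecting how little the measured steps constrain it.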

Compound 4, a percentage reported as activity, at one concentration (the size of the read-out at that concentration, not a potency): 53%
The estimate for compound 4 lay 13 percentage points below the measured number; the range from low to high includes it.
By their numbers in this assay, from the lowest: compounds 1 and 2 (each within the scatter of the next); then compound 3; then compound 4.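

In this assay the change on the carbonyl carbon gives a number 25 percentage points higher from compound 3 to compound 4 (beyond the scatter), the first step among these compounds to touch that carbon and its amide-type nitrogen, and it moves the number towards a weaker effect at the one concentration tested. This single replacement exchanges (3,4-dichlorophenyl)amino, with its hydrogen-bond donor, for 3-(trifluoromethyl)phenyl, which has none. It alters the nitrogen and the outer ring together, the step cannot be divided between them, and the earlier a number 8 percentage points higher from compound 1 to compound 2 (within the scatter) concerns only a ring substituent on a different compound. Nothing available here accounts for the size or direction of this step.

The compounds shown leave open whether the amide-type nitrogen or the outer ring carries the step, a question that a urea keeping 3-(trifluoromethyl)phenyl, or an amide keeping 3,4-dichlorophenyl, would separate. They also leave open how a methylene group or an oxygen atom in place of that nitrogen would read, and whether a hydroxy group in place of the methoxy group would shift the amide compound 4 as it shifts the urea series.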